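The source may hold more compounds than are shown below. What is called first, only, known or untested is meant among the compounds shown, and "the series" means these compounds.

Of the compounds shown here, three sharing one core have been measured in a functional assay on DU-145 cells (Homo sapiens) for inhibition, read by trypan blue exclusion, with a stated time of 96 h; a lower number here means a stronger inhibitor of growth, a higher number a weaker inhibitor of growth. Compound 1 `Cc1ccc(S/C(=C/c2ccc(Cl)cc2)C(=O)c2ccc(Cl)cc2)cc1` gives 10000 nM. Compound 2 `Cc1ccc(CS/C(=C/c2cc([N+](=O)[O-])ccc2F)C(=O)c2ccc(Cl)cc2)cc1` gives 1000 nM. Compound 3 `Cc1ccc(CS/C(=C/c2ccc(O)c(O)c2O)C(=O)c2ccc(Cl)cc2)cc1` gives 50000 nM, the highest number of the three and beyond the scatter from both compound 1 and compound 2. Within the data shown here, the only measured step that bears on this position is a 50-fold higher number from compound 2 to compound 3 (1.70 log units; beyond the scatter). Compound 4 `Cc1ccc(CS/C(=C/c2ccc(Cl)cc2)C(=O)c2ccc(Cl)cc2)cc1` differs from compound 3 by 4-chlorophenyl in place of 2,3,4-trihydroxyphenyl on a double-bonded chain carbon bound to a double-bonded chain carbon. This removes the group whose arrival in compound 3 came with that large rise, so a drop is expected, and compound 1, which also carries a 4-chlorophenyl on a double-bonded chain carbon bound to a double-bonded chain carbon, gives 10000 nM as an anchor. Compound 4 is therefore expected to show a 10-fold lower number from compound 3 to compound 4 (1.00 log units; beyond the scatter), at an estimated 5000 nM within 1000 nM to 25000 nM.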

Compound 4, concentration for 50% growth inhibition: 10000 nM
For compound 4 the middle estimate is 2.0-fold (0.30 log units) below the measured one, within the range that was stated.
By their numbers in this assay, from the lowest: compound 2; then compounds 1 and 4 (each within the scatter of the next); then compound 3.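

Replacing 2,3,4-trihydroxyphenyl with 4-chlorophenyl gives a 5.0-fold lower number from compound 3 to compound 4 (0.70 log units; beyond the scatter), so this position still responds when a ring without hydrogen-bond donors enters. That ring does not match 2-fluoro-5-nitrophenyl, with a 10-fold higher number from compound 2 to compound 4 (1.00 log units; beyond the scatter), which shows that the chlorine-bearing ring alone does not account for the lowest number in the set. On the sulfur, 4-methylbenzyl in place of 4-methylphenyl gives no change at the digits printed from compound 1 to compound 4 (within the scatter), so this change does not register here.

No evidence is available to explain these steps. On these data alone, how an amine or a carboxylic acid on that ring, or a longer chain on the sulfur, would behave remains open.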